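A second ring oxygen on the sulfonamide side chain

This account rests on a few compounds, and the source may have more. Where it says the series, first, only, none or still open, it means among the compounds named here.

Within the data shown here, compound 2 `NC(=O)[C@@H](CCC(F)(F)F)N(C[C@@H]1CCCCO1)S(=O)(=O)c1ccc(Cl)cc1` gives 4.3 in a physicochemical assay for lipophilicity, read by HPLC, measured as octanol-water partition, at pH 7.4 (a higher number here means a more lipophilic compound, a lower number a more polar compound), the higher of the two numbers so far. Compound 1 `CC1(C)CO[C@@H]1CN([C@H](CCC(F)(F)F)C(N)=O)S(=O)(=O)c1ccc(Cl)cc1` gives 3.9 in this assay. Among the measured compounds shown here, the one measured step, a number 0.40 log units higher from compound 1 to compound 2 (beyond the scatter), concerns a different exchange of ring on the same saturated chain carbon and does not speak directly to the change now in question. Compound 3 `NC(=O)[C@@H](CCC(F)(F)F)N(C[C@H]1COCCO1)S(=O)(=O)c1ccc(Cl)cc1` differs from compound 2 as follows: 1,4-dioxan-2-yl in place of oxan-2-yl on a saturated chain carbon bound to a sulfonamide nitrogen. For the measured compounds named here, no measured pair here exchanges one ring oxygen for a second, so the expectation rests on the counted difference alone. For compound 3, the step of a number 0.80 log units lower from compound 2 to compound 3 (beyond the scatter) is expected to be a modest fall, beyond the scatter. Compound 3 is therefore estimated at 3.5 in this assay, within a range from 3 to 4.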

Compound 3, distribution coefficient: 2.75
Compound 3: the middle estimate sits 0.75 log units above what was measured; the measured number lies below the stated range.
By their numbers in this assay, from the lowest: compound 3; then compound 1; then compound 2.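

On a saturated chain carbon bound to a sulfonamide nitrogen, 1,4-dioxan-2-yl in place of oxan-2-yl keeps the six-membered ring and its heavy-atom count, yet gives a number 1.55 log units lower from compound 2 to compound 3 (beyond the scatter) in this assay, a large step where the only earlier one at this place was modest. The same ring against the 3,3-dimethyloxetan-2-yl group gives a number 1.15 log units lower from compound 1 to compound 3 (beyond the scatter), which leaves compound 3 with the lowest number of the three. Nothing in the data shown explains the size of these steps.

The compounds shown leave open how a ring carrying an amine, such as morpholin-2-yl, or an open methoxyethyl chain would read at this place in this assay. They also leave open whether the exchange of oxan-2-yl for 1,4-dioxan-2-yl gives a step of the same size on another core or with the opposite ring stereocentre.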